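The source may report more compounds than this note shows. Statements on the series, on what has been measured and on what is new or still open speak of the compounds shown alone.

Measured compounds:
- Compound 1, `COc1ccc(S(=O)(=O)N2CCc3cccc(-c4ccco4)c32)cc1`, gives 94.5 nM in a functional assay on NCI-H460 cells (Homo sapiens) for inhibition, with a stated time of 72 h; on this read-out higher numbers stand for weaker inhibition and lower numbers for stronger inhibition.
- Compound 2, `COc1ccc(S(=O)(=O)N2CCc3cccc(-c4c(F)c(F)c(F)c(F)c4F)c32)cc1`, gives 4760 nM in this assay.

Of these two values, compound 1 stands lowest, so it is the stronger inhibitor of the pair, and compound 2 lies far above it, well beyond the usual scatter. Compound 3, `COc1ccc(S(=O)(=O)N2CCc3cccc(-c4ccc(O)cc4)c32)cc1`, has not yet been measured. It differs from compound 1 in one place: 4-hydroxyphenyl in place of furan-2-yl on an aromatic carbon. Among the measured compounds shown here, nothing measured so far shows how this particular exchange plays out, so the expectation rests on compound 1 alone. Because compound 1 gives 94.5 nM, a modest weakening is expected, and the step of a 2.1-fold higher number from compound 1 to compound 3 (0.33 log units; beyond the scatter) is estimated to stay close to the scatter rather than approach the gap seen with compound 2. Compound 3 is therefore expected to give about 200 nM, within a range from 50 nM to 1000 nM.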

Compound 3, half-maximal inhibitory concentration: 114 nM
The estimate for compound 3 lay 1.8-fold (0.24 log units) above the measured number; the measured number falls inside the stated range.
By their numbers in this assay, from the lowest: compounds 1 and 3 (each within the scatter of the next); then compound 2.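

In this assay, putting 4-hydroxyphenyl in place of furan-2-yl on this aromatic carbon gives a 1.2-fold higher number from compound 1 to compound 3 (0.08 log units; within the scatter), so the two groups cannot be told apart here. This position therefore holds its low number with either a five-membered aromatic ring with a hetero atom or a six-membered aromatic ring of carbon only, and a six-membered ring alone does not bring the much higher number of compound 2 at 4760 nM. Nothing on hand explains why these two groups match at this position.

From the compounds shown here alone, what the hydroxyl on the ring of compound 3 contributes stays open, as does how a plain phenyl, a 4-aminophenyl or a 4-carboxyphenyl group would compare on this carbon. Going by these compounds, a thiophene ring or a short alkyl chain there is equally open.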